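Moving the chlorine on the benzyl group of compound 3

The source may report more compounds than this note shows. Statements on the series, on what has been measured and on what is new or still open speak of the compounds shown alone.

Measured compounds:
- compound 1, `CC1=C(C(=O)Nc2ccc(Br)cc2)C(c2ccc(Cl)cc2Cl)N=C(SCc2ccc(Cl)cc2)N1`: 22.1%
- compound 2, `COc1ccc(C2N=C(SCc3ccccc3)NC(C)=C2C(=O)Nc2ccc(Br)cc2)cc1`: 5.6%
- compound 3, `COc1ccc(C2N=C(SCc3ccccc3Cl)NC(C)=C2C(=O)Nc2ccc(Br)cc2)cc1`: 7.2%

All three were tested in a functional assay on the whole organism (artery, strain albino) with Rattus norvegicus as the target, with a stated time of 900 min, at a dose of 10 mg/kg by the oral route; a lower number here means less inhibition, a higher number more inhibition at the dose given (going by the name of the read-out). Compound 3 gives 7.2%, which lies within the scatter of compound 2 and well below compound 1, whose number is beyond the scatter away. Going by the values given here, the one single-point step among the measured compounds is a number 1.6 percentage points higher from compound 2 to compound 3 (within the scatter), which adds a chlorine to the benzyl ring and changes nothing that could be told from repeat measurements.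

Compound 4, `COc1ccc(C2N=C(SCc3ccc(Cl)cc3)NC(C)=C2C(=O)Nc2ccc(Br)cc2)cc1`, has not yet been measured. It differs from compound 3 only in that (4-chlorophenyl in place of 2-chlorophenyl on a saturated chain carbon bound to a sulfur); the two compounds have the same atoms, joined differently. Among the compounds with values here, no measured step in this assay moves the chlorine from one position on this ring to another, and compound 1, the only compound carrying a 4-chlorobenzyl group, differs from compound 4 in a second place as well, so its higher number cannot be credited to the benzyl chlorine alone. Within the data shown here, the only step that bears on it, from compound 2 to compound 3, stayed within the scatter.

I therefore expect compound 4 to sit close to compound 3, with a step of a number 1.8 percentage points higher from compound 3 to compound 4 (within the scatter) that does not go beyond the scatter. My estimate for compound 4 in this assay is 9%, ranging from 0% to 20%.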

Compound 4, a percentage reported as inhibition, in the whole organism at one dose (the size of the read-out at that dose, not a potency): 20%
Estimate against measurement, compound 4: 11 percentage points below; measured number inside the range.
By their numbers in this assay, from the lowest: compounds 2 and 3 (each within the scatter of the next); then compounds 4 and 1 (each within the scatter of the next).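

In this assay the change from 2-chlorobenzyl to 4-chlorobenzyl amounts to a number 12.8 percentage points higher from compound 3 to compound 4 (beyond the scatter), so two compounds with the same atoms, joined differently, now stand apart, something the earlier chlorine step could not show. Set against the plain benzyl group, the 2-chlorobenzyl group gave only a number 1.6 percentage points higher from compound 2 to compound 3 (within the scatter) while the 4-chlorobenzyl group gives a number 14.4 percentage points higher from compound 2 to compound 4 (beyond the scatter), which means that at this place on the sulfur chain a chlorine changes the number in one of the two tested placements and not in the other. The other ring group counts for little in this pair: 4-methoxyphenyl in place of 2,4-dichlorophenyl on a saturated ring carbon gives a number 2.1 percentage points lower from compound 1 to compound 4 (within the scatter), so with a 4-chlorobenzyl group present, compound 1 and compound 4 cannot be told apart.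

Nothing shown gives a reason why the two chlorine placements differ. Also open, on these data alone, is whether the gain belongs to chlorine itself, since a fluorine, a bromine or a methoxy group in place of the chlorine of the 4-chlorobenzyl group would be needed to tell.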